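Cytotoxicity outlook for a methoxyphenyl chalcone analogue

The source may hold more compounds than are shown below. What is called first, only, known or untested is meant among the compounds shown, and "the series" means these compounds.

Measured so far in an ADME assay on Vero cells (Chlorocebus sabaeus) for cytotoxicity, read by MTT assay; on this read-out higher numbers stand for weaker inhibition and lower numbers for stronger inhibition:
compound 1 `C=CCOc1cc(OC)c(C(=O)/C=C/c2ccc(F)cc2)c(OCC=C)c1` gives 13600 nM
compound 2 `C=CCOc1cc(OC)c(C(=O)/C=C/c2ccco2)c(OCC=C)c1` gives 191000 nM
compound 3 `C=CCOc1cc(OC)c(C(=O)/C=C/C=C/c2ccccc2)c(OCC=C)c1` gives "not determined" (no result reported)

All three share a common core and differ only in the group carried at the far end of the double-bonded chain. Compound 1 has the lowest number of the two compounds with a result; compound 2 sits well above it, with a 14-fold higher number from compound 1 to compound 2 (1.15 log units; beyond the scatter). Compound 3 offers no number for comparison.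

Compound 4 `C=CCOc1cc(OC)c(C(=O)/C=C/c2cccc(OC)c2)c(OCC=C)c1` is the next analogue, differing from compound 1 as follows: 3-methoxyphenyl in place of 4-fluorophenyl on a double-bonded chain carbon bound to a double-bonded chain carbon.

Going by the values given here, the only measured step, from compound 1 to compound 2, exchanged the whole aromatic group for a different type of ring, and that exchange moved the number a great deal. The change to compound 4 is gentler: one six-membered aromatic ring of carbon only stays in place, and only its substituent shifts. Among the compounds with values here, no measured pair shows what such a substituent swap does here, so a step of modest size is expected, with the direction uncertain; a drift toward a slightly higher number, a 1.5-fold higher number from compound 1 to compound 4 (0.17 log units; within the scatter), is the estimate. For compound 4 the expected value in this assay is 20000 nM, within a range from 6000 nM to 70000 nM.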

Compound 4, half-maximal inhibitory concentration: 142000 nM
For compound 4 the middle estimate is 7.1-fold (0.85 log units) below the measured one; measured number above the stated range.
By their numbers in this assay, from the lowest: compound 1; then compounds 4 and 2 (each within the scatter of the next).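

In this assay keeping one six-membered aromatic ring of carbon only does not keep the number close, as 3-methoxyphenyl in place of 4-fluorophenyl gives a 10-fold higher number from compound 1 to compound 4 (1.02 log units; beyond the scatter) and so a large step without any change of ring type. The other step at this place, a 1.3-fold lower number from compound 2 to compound 4 (0.13 log units; within the scatter), shows that two quite different groups, furan-2-yl and 3-methoxyphenyl, cannot be told apart here, while 4-fluorophenyl stands apart from both. Going by these compounds alone, nothing at hand explains why this swap moves the number so far.

The fluorine leaves and the methoxy enters in the same step, and the compounds shown cannot separate the two. As far as these compounds go, how a plain phenyl group at this place, or a phenyl carrying an amine or a carboxylic acid, would compare also stays open.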